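The source may hold more compounds than are shown below. What is called first, only, known or untested is meant among the compounds shown, and "the series" means these compounds.

Compound 1 `C#Cc1cccc(Nc2ncnc3c(OC)c(OC)c(OC)cc23)c1`: in a functional assay on SGC-7901 cells (Homo sapiens) for antiproliferative activity, read by MTT assay, with a stated time of 72 h (on this read-out lower numbers stand for stronger inhibition and higher numbers for weaker inhibition), compound 1 gives 5820 nM.
Compound 2 `COc1cc2c(Nc3ccc(Br)c(F)c3)ncnc2c(OC)c1OC`: in this assay compound 2 gives only a limit, > 30000 nM.

Compound 1 holds the only actual number shown. The remaining value sits at the limit of > 30000 nM in this assay, at which 1 of the 2 values shown sits. Compound 3 `COc1cc2c(Nc3cccc(F)c3F)ncnc2c(OC)c1OC` differs from compound 1 by 2,3-difluorophenyl in place of 3-ethynylphenyl on a nitrogen on an aromatic ring. Among the compounds with values here, the one measured step at this place, an at least 5.1-fold higher number from compound 1 to compound 2 (0.71 log units; beyond the scatter), was a marked weakening when a halogenated phenyl entered. A weakening step is therefore expected for compound 3, a 3.4-fold higher number from compound 1 to compound 3 (0.54 log units; beyond the scatter). Compound 3 is estimated at 20000 nM, range 7000 nM to 60000 nM, with a fair chance that only a limit is reported.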

Compound 3, half-maximal inhibitory concentration: > 30000 nM
Compound 3 gave a limit, no number; the forecaster's own chance of this, stated with the estimate: 40%; middle value at least 1.5-fold (0.17 log units) away from the limit.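

At the nitrogen on the aromatic ring, 2,3-difluorophenyl in place of 3-ethynylphenyl gives an at least 5.1-fold higher number from compound 1 to compound 3 (0.71 log units; beyond the scatter) in this assay. The weakening seen with 4-bromo-3-fluorophenyl therefore does not require bromine: a phenyl carrying fluorine alone shows it too. The step from compound 2 to compound 3 cannot be read, and the two halogenated phenyl groups cannot be ranked, with both compounds at a limit: the limit of > 30000 nM in this assay, at which 2 of the 3 values shown sit.

Still open, from the compounds shown here alone, is whether the stronger value of compound 1 rests on the ethynyl group itself. A phenyl carrying a nitrile or an amine in its stead would test this.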